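Extending the amide side chain of compound 3 by a methyl ester

The source may hold more compounds than are shown below. What is called first, only, known or untested is meant among the compounds shown, and "the series" means these compounds.

Of the compounds shown here, three sharing one core have been measured in an ADME assay on CEM-SS cells (Homo sapiens) for cytotoxicity, read by XTT assay, with a stated time of 6 days; a lower number here means that less compound is tolerated, a higher number that more compound is tolerated. Compound 1 `CCCC(=O)OCSc1ccccc1C(=O)NCCC(N)=O` in this assay gives only a limit, > 100 uM. Compound 2 `CCCC(=O)OCSc1ccccc1C(=O)NCC(N)=O` in this assay likewise gives a limit, > 100 uM. Compound 3 `CCCC(=O)OCSc1ccccc1C(=O)NCC(=O)NC` in this assay also gives a limit, > 100 uM. All three values sit at the limit of > 100 uM in this assay, at which 3 of the 3 values shown sit, so the steps between them, a step that the two limits leave unreadable from compound 1 to compound 2, a step that the two limits leave unreadable from compound 1 to compound 3 and a step that the two limits leave unreadable from compound 2 to compound 3, cannot be read in size or direction.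

Compound 4 `CCCC(=O)OCSc1ccccc1C(=O)NCC(=O)NCC(=O)OC` has not yet been measured in this assay. It differs from compound 3 by methoxycarbonyl in place of hydrogen on a saturated chain carbon bound to an amide-type nitrogen. Within the data shown here, none of the measured steps is readable, so they give no size to expect from this change. Among the measured compounds shown here, they show only that every change made so far within this set has left the value at the limit. The step is therefore expected to be small, a step that the limit leaves unreadable from compound 3 to compound 4, with compound 4 most likely again reaching the limit. For compound 4 in this assay the expected value is 150 uM, estimated to lie between 60 uM and 400 uM.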

Compound 4, half-maximal toxic concentration: > 100 uM
Compound 4: a limit, no number; the forecaster's own chance of this, stated with the estimate: 85%; the middle value is on the limit's open side.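

In this assay compound 4 gives only a limit, so its steps from compound 1, compound 2 and compound 3 cannot be read in size or direction: the limit of > 100 uM in this assay, at which 4 of the 4 values shown sit.

The compounds shown leave open at what concentration any of these four compounds reaches its half-maximal toxic effect.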